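A phenyl for chlorophenyl swap in the aniline

A few compounds are considered here, and "the series" means these few. Any claim that something is new, unique, unknown or untested is made for them only; others in the source may bear on it.

Of the compounds shown here, three of one series have been measured in a functional assay on A-431 cells (Homo sapiens) for antiproliferative activity, read by MTT assay, with a stated time of 72 h; on this read-out higher numbers stand for weaker inhibition and lower numbers for stronger inhibition. Compound 1 `COc1cc2ncnc(Nc3ccc(Cl)c(C(F)(F)F)c3)c2cc1OCCCCC(=O)Nc1ccc(S(N)(=O)=O)cc1` gives 3910 nM. Compound 2 `COc1cc2ncnc(Nc3ccc(Cl)cc3)c2cc1OCCCCC(=O)Nc1ccc(S(N)(=O)=O)cc1` gives 7120 nM, and compound 3 `COc1cc2ncnc(Nc3ccc(OC(F)(F)F)cc3)c2cc1OCCCCC(=O)Nc1ccc(S(N)(=O)=O)cc1` gives 22500 nM. Of these three numbers compound 2 holds the second highest; its nearest neighbour is compound 1, a 1.8-fold higher number from compound 1 to compound 2 (0.26 log units; within the scatter), and its furthest is compound 3, a 3.2-fold higher number from compound 2 to compound 3 (0.50 log units; beyond the scatter).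

Compound 4 `COc1cc2ncnc(Nc3ccccc3)c2cc1OCCCCC(=O)Nc1ccc(S(N)(=O)=O)cc1` is the next member and has not yet been measured in this assay. Compared with compound 2 it carries hydrogen in place of chloro on an aromatic carbon.

Going by the values given here, two measured steps bear on this change. Taking a trifluoromethyl off the aromatic ring, a 1.8-fold higher number from compound 1 to compound 2 (0.26 log units; within the scatter), stayed within the scatter. Replacing the chloro by trifluoromethoxy, a 3.2-fold higher number from compound 2 to compound 3 (0.50 log units; beyond the scatter), weakened inhibition modestly. Removing the chloro altogether lies between these two kinds of change, and the available data cannot separate a small loss from no change at all. The author therefore expects the step from compound 2 to compound 4 to be a modest rise in the number, a 1.7-fold higher number from compound 2 to compound 4 (0.23 log units; within the scatter), leaning toward weaker inhibition. Compound 4 is estimated to give 12000 nM in this assay, within a range from 5000 nM to 30000 nM.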

Compound 4, half-maximal inhibitory concentration: 25200 nM
For compound 4 the middle estimate is 2.1-fold (0.32 log units) below the measured one, within the range that was stated.
By their numbers in this assay, from the lowest: compounds 1 and 2 (each within the scatter of the next); then compounds 3 and 4 (each within the scatter of the next).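

In this assay, the chloro on this aromatic carbon proves to matter: taking it off, a 3.5-fold higher number from compound 2 to compound 4 (0.55 log units; beyond the scatter), goes beyond the scatter, whereas the earlier loss of trifluoromethyl from compound 1 stayed within it. Trifluoromethoxy on the same carbon offers no measurable advantage over hydrogen, since a 1.1-fold higher number from compound 3 to compound 4 (0.05 log units; within the scatter) lies within the scatter, so among the three para groups shown only chloro stands apart from hydrogen. With the aniline ring bare of both chloro and trifluoromethyl, the step is a 6.4-fold higher number from compound 1 to compound 4 (0.81 log units; beyond the scatter), again beyond the scatter; no measurement at hand gives a reason for any of these differences.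

The compounds shown leave open whether the effect is particular to chloro or would also appear with fluoro, bromo, methyl or methoxy on that carbon. They also leave open how a trifluoromethyl group alone on the aniline ring, without the chloro, would compare with compound 4, and whether the chloro step would keep its size with a shorter or longer chain joining the core to the sulfonamide-bearing ring.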